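Hydroxy to benzyloxy on compound 2

The source may hold more compounds than are shown below. What is called first, only, known or untested is meant among the compounds shown, and "the series" means these compounds.

Measured in a functional assay on BV-2 cells (Mus musculus) for inhibition, read by Griess assay, with a stated time of 24 h; a lower number here means a stronger inhibitor, a higher number a weaker inhibitor:
- compound 1 `COc1ccc(Br)cc1-c1cc(CO)on1`: > 200000 nM
- compound 2 `C=CCc1ccc(OC)c(-c2cc(CO)on2)c1`: > 200000 nM
- compound 3 `C=CCc1ccc(O)c(-c2cc(CO)on2)c1`: > 200000 nM

Compound 2 has only a limit, > 200000 nM. Compound 1 and compound 3 also give limits, not numbers, so the whole series sits at the limit of > 200000 nM in this assay, at which 3 of the 3 values shown sit.

Compound 4 `C=CCc1ccc(OC)c(-c2cc(COCc3ccccc3)on2)c1` differs from compound 2 by one change, hydroxy to benzyloxy: benzyl in place of hydrogen on an oxygen on a saturated carbon.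

Two measured steps exist, a step that the two limits leave unreadable from compound 1 to compound 2 and a step that the two limits leave unreadable from compound 2 to compound 3. As far as these compounds go, neither gives a size, and neither lies at this oxygen on a saturated carbon, so the size of the next step in this assay remains open. A further limit is quite possible, and any readable value would mean stronger inhibition. Expected, with wide uncertainty, is an at least 1.6-fold lower number from compound 2 to compound 4 (0.22 log units; that floor lies within the scatter). For compound 4 the estimate is 120000 nM, with an expected range of 25000 nM to 300000 nM.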

Compound 4, half-maximal inhibitory concentration: > 200000 nM
Compound 4: a limit, no number; the forecaster's own chance of this, stated with the estimate: 50%; at least 1.6-fold (0.22 log units) between middle value and limit.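

For the compounds shown here, compound 4 gives the limit > 200000 nM and compound 2 is also only a limit, so no step between them can be read. In this assay the compounds shown leave open which structural change, if any, would give a readable value.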